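From butoxy to (3-carboxypropyl)amino on a carbonyl carbon

A few compounds are considered here, and "the series" means these few. Any claim that something is new, unique, unknown or untested is made for them only; others in the source may bear on it.

In a functional assay on MT4 cells (Homo sapiens) for cytotoxicity (a higher number here means that more compound is tolerated, a lower number that less compound is tolerated), compound 3 (`CCCCOC(=O)OCC1OC(n2cc(C)c(=O)[nH]c2=O)CC1N=[N+]=[N-]`) gives > 50000 nM, which is a limit and not a number. Compound 1 (`Cc1cn(C2CC(N=[N+]=[N-])C(COC(=O)OCCCCCCCCO)O2)c(=O)[nH]c1=O`) also gives a limit, > 50000 nM. Compound 2 (`Cc1cn(C2CC(N=[N+]=[N-])C(COC(=O)NCCCC(=O)OC(C)(C)C)O2)c(=O)[nH]c1=O`) gives a limit too, > 50000 nM. Compound 3 therefore stands with the others, at the limit of > 50000 nM in this assay, at which 3 of the 3 values shown sit.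

Compound 4 (`Cc1cn(C2CC(N=[N+]=[N-])C(COC(=O)NCCCC(=O)O)O2)c(=O)[nH]c1=O`) has (3-carboxypropyl)amino in place of butoxy on a carbonyl carbon. Within the data shown here, the one measured step that bears on this change is a step that the two limits leave unreadable from compound 1 to compound 3, and it offers no size to carry over. With every measured value at the limit, no step beyond the scatter is expected in this assay. The expected step is a number no higher from compound 3 to compound 4 (the limit leaves the size open). For compound 4 the estimate is 50000 nM, with an expected range of 25000 nM to 100000 nM.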

Compound 4, half-maximal cytotoxic concentration: > 50000 nM
Compound 4: only a limit was reported; the forecaster's own chance of this, stated with the estimate: 85%; the middle value sits exactly at the limit.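

No step can be read in this assay: the steps from compound 1, compound 2 and compound 3 to compound 4 all join two limits. The compounds shown leave open where the half-maximal cytotoxic concentration of any of them lies.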